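The compounds below may be only part of what the source reports. "The series", "measured", "known", "first", "only" and "open" are said of these compounds alone.

Measured in an ADME assay on MRC5 cells (Homo sapiens) for cytotoxicity, read by resazurin assay, with a stated time of 7 days; a higher number here means that more compound is tolerated, a lower number that less compound is tolerated:
- compound 1 `COc1ccccc1NC(=S)Nc1ccc2nc(Oc3ccc(F)cc3C(C)O)c(Cc3ccccc3)cc2c1`: 16000 nM
- compound 2 `COc1ccc(NC(=S)Nc2ccc3nc(Oc4ccc(F)cc4C(C)O)c(Cc4ccccc4)cc3c2)cc1`: 42300 nM
- compound 3 `COc1nc2ccc(Br)cc2cc1C(c1ccccc1)n1cnc([N+](=O)[O-])c1`: 64000 nM

In this assay, compound 2 cannot be told apart from compound 3, and both numbers are higher than that of compound 1. The next compound to consider is compound 4 `COc1ccccc1NC(=O)Nc1ccc2nc(Oc3ccc(F)cc3C(C)O)c(Cc3ccccc3)cc2c1`. Going from compound 2 to compound 4 brings two changes at once, as one group is exchanged for another on a nitrogen on an aromatic ring: a group of 11 heavy atoms (8 carbon, 1 nitrogen, 2 oxygen; one six-membered aromatic ring of carbon only) in place of a group of 11 heavy atoms (8 carbon, 1 nitrogen, 1 oxygen, 1 sulfur; one six-membered aromatic ring of carbon only), on a nitrogen on an aromatic ring. The methoxy group returns to the arrangement of compound 1, and oxygen takes the place of sulfur.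

Among the measured compounds shown here, only one measured step bears on this: a 2.6-fold higher number from compound 1 to compound 2 (0.42 log units; beyond the scatter). It covers the methoxyphenyl change alone, and undoing it points to a lower number. For the measured compounds named here, no measured pair shows the exchange of sulfur for oxygen, so that part stays open and the range must be wide. The estimated step is a 1.7-fold lower number from compound 2 to compound 4 (0.23 log units; within the scatter). For compound 4, the expected value is 25000 nM, with an estimated range of 9000 nM to 64000 nM.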

Compound 4, half-maximal cytotoxic concentration in the MRC5 assay: 6210 nM
Compound 4: the middle estimate sits 4.0-fold (0.60 log units) above what was measured, and the stated range ends above it.
By their numbers in the MRC5 assay, from the lowest: compound 4; then compound 1; then compounds 2 and 3 (each within the scatter of the next).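

The exchange of sulfur for oxygen can now be read on its own, since compounds 1 and 4 keep the same 2-methoxyphenyl arrangement: in the MRC5 assay, there is a 2.6-fold lower number from compound 1 to compound 4 (0.41 log units; beyond the scatter). The step with the methoxy group also moved is a 6.8-fold lower number from compound 2 to compound 4 (0.83 log units; beyond the scatter), so sulfur to oxygen at this nitrogen leaves less compound tolerated in both comparisons. In a physicochemical assay for lipophilicity (a higher number here means a more lipophilic compound, a lower number a more polar compound), compound 2 gives 7.86 and compound 4 gives 6.72. Oxygen also gives a more polar compound in the physicochemical assay: the measured partition coefficient of compound 2, 7.86, and of compound 4, 6.72, a number 1.14 log units lower (beyond the scatter)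

On these data alone, with a single lipophilicity pair, it stays open whether this polarity has any link to the lower tolerated concentration. Also open, as far as these compounds go, are how a 4-methoxyphenyl group behaves with oxygen in place of sulfur, and whether a guanidine, with nitrogen at that spot, would follow the same direction.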